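The source may report more compounds than this note shows. Statements on the series, on what has been measured and on what is new or still open speak of the compounds shown alone.

Measured in a functional assay on DU-145 cells (Homo sapiens) for inhibition, read by trypan blue exclusion, with a stated time of 96 h; a lower number here means a stronger inhibitor of growth, a higher number a weaker inhibitor of growth:
Compound 1 `Cc1ccc(S(=O)(=O)/C(=C/c2ccc(C)s2)C(=O)c2ccc(Br)cc2)cc1` gives 25000 nM
Compound 2 `Cc1ccc(S(=O)(=O)/C(=C/c2ccc(Br)cc2)C(=O)c2ccc(Br)cc2)cc1` gives 10000 nM

Compound 2 holds the lower of the two numbers at 10000 nM as measured. Within the data shown here, compound 3 `Cc1ccc(S(=O)(=O)/C(=C/c2c[nH]c3ccc(Cl)cc23)C(=O)c2ccc(Br)cc2)cc1` comes next, and the change is 5-chloro-1H-indol-3-yl in place of 4-bromophenyl on a double-bonded chain carbon bound to a double-bonded chain carbon at the same place as the only measured step. That step is a 2.5-fold lower number from compound 1 to compound 2 (0.40 log units; beyond the scatter) and is modest. Among the measured compounds shown here, no measured compound carries the entering group, so this step is only a rough guide. A similar modest move to a lower number is expected, namely a 2.9-fold lower number from compound 2 to compound 3 (0.46 log units; beyond the scatter) as estimated. Compound 3 is expected at 3500 nM in this assay with an estimated range from 700 nM to 15000 nM for this value.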

Compound 3, concentration for 50% growth inhibition: 10000 nM
Estimate against measurement, compound 3: 2.9-fold (0.46 log units) below; the measured number falls inside the stated range.
By their numbers in this assay, from the lowest: compounds 2 and 3 (each within the scatter of the next); then compound 1.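

In this assay the step of no change at the digits printed from compound 2 to compound 3 (within the scatter) shows that 5-chloro-1H-indol-3-yl, with its second ring and hydrogen-bond donor, reads the same as 4-bromophenyl on this double-bonded chain carbon. The step of a 2.5-fold lower number from compound 1 to compound 3 (0.40 log units; beyond the scatter) for the same entering group puts 5-methylthiophen-2-yl apart from both larger groups at this place. No measured evidence accounts for these readings.

As far as these compounds go, how an amine or a carboxylic acid would read on this carbon remains open. So does whether the 4-bromophenyl on the carbonyl side shapes these readings.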